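The source may hold more compounds than are shown below. What is called first, only, known or untested is meant among the compounds shown, and "the series" means these compounds.

Measured in a physicochemical assay for solubility, read by HPLC, in phosphate buffer, measured as kinetic solubility, at pH 7.4; on this read-out higher numbers stand for higher solubility and lower numbers for lower solubility:
- Compound 1 `CCC(=O)c1cc(-c2ccc(Cl)cc2)n(-c2cccc(S(N)(=O)=O)c2)c1C`: 200 nM
- Compound 2 `NS(=O)(=O)c1ccc(-c2cc(C(=O)C3CC3)nn2-c2ccc(Cl)cc2)cc1`: 25600 nM

Compound 2 holds the higher of these two numbers, and its gap to compound 1 lies well beyond the usual scatter of repeat measurements. The two compounds differ in more than one place, so they offer no direct guide to the next change. Compound 3 `NS(=O)(=O)c1ccc(-c2cc(C(=O)N3CCCC3)nn2-c2ccc(Cl)cc2)cc1` keeps the rest of compound 2 but has pyrrolidin-1-yl in place of cyclopropyl on a carbonyl carbon. No change beyond the scatter is expected, with an estimated step of a 1.2-fold higher number from compound 2 to compound 3 (0.07 log units; within the scatter). For compound 3, the estimated value is 30000 nM, within an expected range of 10000 nM to 80000 nM.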

Compound 3, solubility: 57900 nM
Compound 3: the middle estimate sits 1.9-fold (0.29 log units) below what was measured, within the range that was stated.
By their numbers in this assay, from the lowest: compound 1; then compound 2; then compound 3.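

Swapping cyclopropyl for pyrrolidin-1-yl on a carbonyl carbon is the first change here made in one place only, and in this assay it gives a 2.3-fold higher number from compound 2 to compound 3 (0.35 log units; beyond the scatter) as a modest step. This position therefore accepts a larger ring holding a nitrogen with no loss on this read-out. No measurement at hand explains the step.

A single step cannot separate the effect of ring size from that of the ring nitrogen. Piperidin-1-yl, morpholin-4-yl or dimethylamino on the same carbonyl carbon would begin to tell these apart.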